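Swapping methoxy for hydroxymethyl on the benzyl group

This account rests on a few compounds, and the source may have more. Where it says the series, first, only, none or still open, it means among the compounds named here.

Compound 1 `Cc1nc(-c2nc(C(F)(F)F)no2)c(N)c2c1C(=O)N(Cc1ccccc1)C2=O`: in a physicochemical assay for solubility, using the shake flask method, in simulated intestinal fluid, measured as kinetic solubility, with a stated time of 2 h, at 25 degrees C, at pH 6.5 (on this read-out lower numbers stand for lower solubility and higher numbers for higher solubility), compound 1 gives < 5000 nM, which is a limit of the assay rather than a number.
Compound 2 `COc1ccc(CN2C(=O)c3c(C)nc(-c4nc(C)no4)c(N)c3C2=O)cc1`: in this assay compound 2 gives < 5000 nM, again a limit and not a number.

Within the data shown here, compound 2 thus stands at the limit, as does the only other value shown (the limit of < 5000 nM in this assay, at which 2 of the 2 values shown sit). Compound 3 `Cc1noc(-c2nc(C)c3c(c2N)C(=O)N(Cc2ccc(CO)cc2)C3=O)n1` differs from compound 2 in one place: hydroxymethyl in place of methoxy on an aromatic carbon. Among the measured compounds shown here, no step between measured compounds is available, so the size of the change in this assay cannot be read from data; the step expected is a step that the limit leaves unreadable from compound 2 to compound 3, which is within the scatter. Compound 3 is estimated at 4000 nM, with a range from 1000 nM to 15000 nM, and is likely to be reported as a limit again.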

Compound 3, solubility: < 5000 nM
Compound 3 gave a limit, no number (the forecaster's own chance of this, stated with the estimate: 60%); the middle value lies beyond the limit too.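

No step can be read from compound 2 to compound 3, as neither gives a number: the limit of < 5000 nM in this assay, at which 3 of the 3 values shown sit.

As far as these compounds go, whether hydroxymethyl in place of methoxy shifts the result in this assay at all stays open.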